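Bromine on the Aromatic Ring: Two Matched Pairs

A few compounds are considered here, and "the series" means these few. Any claim that something is new, unique, unknown or untested is made for them only; others in the source may bear on it.

Of the compounds shown here, three have so far been tested in a functional assay on MCF7 cells (Homo sapiens) for antiproliferative activity, read by MTT assay, with a stated time of 72 h; on this read-out lower numbers stand for stronger inhibition and higher numbers for weaker inhibition. Compound 1 `O=C1NC(=O)/C(=C/C2=Cc3ccccc3OC2)S1` is the plain parent of the first core; in this assay compound 1 gives 99400 nM. Compound 3 `O=C1NC(=O)/C(=C/C2=Cc3cc(Br)ccc3OC2)S1` differs from it in a single spot, namely (bromo in place of hydrogen on an aromatic carbon). In this assay compound 3 gives 57900 nM. The resulting step is a 1.7-fold lower number from compound 1 to compound 3 (0.23 log units; within the scatter), so the extra bromine has made no change that can be trusted against the repeat-to-repeat spread of the measurement.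

Compound 2 `O=C1NC(=S)S/C1=C\C1=Cc2ccccc2OC1` is built on a second core; the difference between the two cores is not broken down here. In this assay compound 2 gives 68700 nM, a number that sits within the usual scatter of both compound 1 and compound 3.

Compound 4 `O=C1NC(=S)S/C1=C\C1=Cc2cc(Br)ccc2OC1` is the bromine-bearing counterpart of compound 2, and its difference from compound 2 is bromo in place of hydrogen on an aromatic carbon. The surroundings of the new group are described in the same words for both pairs, so the change is the same as that from compound 1 to compound 3.

For compound 4 a step of a 1.6-fold lower number from compound 2 to compound 4 (0.21 log units; within the scatter) is expected, because a 1.7-fold lower number from compound 1 to compound 3 (0.23 log units; within the scatter) shows what this same change did on the first core. Compound 4 is therefore estimated at 42000 nM, with a plausible range from 20000 nM to 95000 nM.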

Compound 4, half-maximal inhibitory concentration: 40400 nM
For compound 4 the middle estimate is 1.0-fold (0.02 log units) above the measured one, and the stated range covers the measured number.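

In this assay the new step is a 1.7-fold lower number from compound 2 to compound 4 (0.23 log units; within the scatter), and set beside the earlier step on the other core, the two agree: the same change on two cores in this assay, a 1.7-fold lower number (0.23 log units; within the scatter) from compound 1 to compound 3 and a 1.7-fold lower number (0.23 log units; within the scatter) from compound 2 to compound 4, 1.0-fold (0.00 log units) apart, within the scatter of two such steps

For these two matched pairs, then, bromo in place of hydrogen on an aromatic carbon gave a step of the same size on both cores, and the step seen on the first core was a fair guide to the step on the second. This does not show that bromine truly shifts the number on either core: each step lies within the usual scatter of repeated measurements, so the agreement is between two small steps that cannot be told apart from noise, and a step that is small on both cores is an easy thing to match. Two pairs also make no rule for other cores, and they say nothing about why the steps agree.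

The compounds shown leave open whether any other group at this same aromatic carbon, such as a chlorine, an amine, a carboxylic acid or a longer chain, would give a step beyond the scatter. They also leave open whether such a step would carry from one core to the other as closely as this one did.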